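Chain Length and Ring Configuration in a Small Series

A few compounds are considered here, and "the series" means these few. Any claim that something is new, unique, unknown or untested is made for them only; others in the source may bear on it.

Four compounds share one core, a saturated oxygen-containing ring carrying an amine, a hydroxyl and a chain ending in a second amine. Compound 1 is `CCCCCCCCCCNC[C@@H]1OC[C@H](N)[C@@H]1O`, compound 2 is `CCCCCCCCNC[C@@H]1OC[C@H](N)[C@@H]1O`, and compound 3 is `CCCCCCCCNC[C@@H]1OC[C@H](N)[C@H]1O`. Compound 4, `CCCCCCCCCCNC[C@@H]1OC[C@H](N)[C@H]1O`, has not yet been measured.

In a functional assay on B16-F10 cells (Mus musculus) for antiproliferative activity, read by MTT assay, with a stated time of 72 h (on this read-out lower numbers stand for stronger inhibition and higher numbers for weaker inhibition), compound 1 gives 29600 nM. Compound 2 reaches only the limit of the assay, > 128000 nM, and no number. Compound 3 likewise reaches only the limit, > 128000 nM.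

The change from compound 2 to compound 1 is ethyl in place of hydrogen on a saturated chain carbon, eight bonds along the chain from an amine nitrogen, and it brings an at least 4.3-fold lower number from compound 2 to compound 1 (0.63 log units; beyond the scatter). Compounds 2 and 3 differ in their cores as follows: the two compounds have the same atoms and bonds and differ only in configuration as drawn: 1 of 3 stereo elements differ; a stereocentre at a saturated ring carbon is drawn S in compound 2 and R in compound 3. The step between them is a step that the two limits leave unreadable from compound 2 to compound 3, which cannot be read because of the limit of > 128000 nM in this assay, at which 2 of the 3 values shown sit, the limit at which both sit.

Compound 4 differs from compound 3 by ethyl in place of hydrogen on a saturated chain carbon, eight bonds along the chain from an amine nitrogen, the same change in the same place as from compound 2 to compound 1, but on the other configuration of the ring. The step is expected to be an at least 2.8-fold lower number from compound 3 to compound 4 (0.45 log units; beyond the scatter), resting on the lengthening of the chain from compound 2 to compound 1 giving an at least 4.3-fold lower number from compound 2 to compound 1 (0.63 log units; beyond the scatter), while compound 3 sits at > 128000 nM as a limit. Compound 4 is therefore estimated at 45000 nM, between 15000 nM and 150000 nM.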

Compound 4, half-maximal inhibitory concentration: > 128000 nM
Compound 4 was reported as a limit (the forecaster's own chance of this, stated with the estimate: 25%); at least 2.8-fold (0.45 log units) between middle value and limit.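

In this assay compound 4 gives > 128000 nM, which is a limit and not a number. The ethyl change gave a readable drop in the number on the core of compound 1, but no such drop appears on the core of compound 4, and the steps between compounds that both sit at the limit cannot be read, so a real gain on this configuration is neither shown nor ruled out: the limit of > 128000 nM in this assay, at which 3 of the 4 values shown sit. What can be read is the effect of the ring configuration with the longer chain in place, where one ring stereocentre drawn R instead of S brings an at least 4.3-fold higher number from compound 1 to compound 4 (0.63 log units; beyond the scatter), so within this one pair of cores the gain from the ethyl change is seen only on the configuration drawn S.

The compounds shown leave open whether a still longer chain, for example butyl in place of ethyl on a saturated chain carbon, eight bonds along the chain from an amine nitrogen, would bring the core of compound 4 to a measurable number. They also leave open how the core of compound 1 would respond to a carboxylic acid at the end of the chain in place of the plain carbon chain end.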